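This account rests on a few compounds, and the source may have more. Where it says the series, first, only, none or still open, it means among the compounds named here.

Measured compounds:
- compound 1, `COc1ccc(-c2ccnc(C(=O)N(C)C)c2)cc1S(=O)(=O)Nc1cccc(NCCNC(=O)c2cccc(C)c2)c1`, in a functional assay on CHO-RD-HGA16 cells for agonist activity at Orexin/Hypocretin receptor type 1 (Homo sapiens), read by fluorescence and calcium flux, with a stated time of 30 min (a higher number here means that more compound is needed for the effect, a lower number that less compound is needed), gives 5170 nM
- compound 2, `COc1ccc(-c2csc(C(=O)N(C)C)n2)cc1S(=O)(=O)Nc1cccc(NCCNC(=O)c2cccc(C)c2)c1`, gives in this assay 928 nM
- compound 3, `COc1ccc(-c2cccc(C(=O)NCCN(C)C)c2)cc1S(=O)(=O)Nc1cccc(NCCNC(=O)c2cccc(C)c2)c1`, is recorded in this assay only as a limit, > 10000 nM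

Compound 3 thus sits at the point described by the limit of > 10000 nM in this assay, at which 1 of the 3 values shown sits, and no number is known for it. Going by the values given here, the one step measured here, a 5.6-fold lower number from compound 1 to compound 2 (0.75 log units; beyond the scatter), concerns the aryl ring and not the amide tail, so no measured step bears on the change to compound 4, `COc1ccc(-c2cccc(C(=O)NCc3ccccn3)c2)cc1S(=O)(=O)Nc1cccc(NCCNC(=O)c2cccc(C)c2)c1`, which is pyridin-2-yl in place of (dimethylamino)methyl on a saturated chain carbon bound to an amide-type nitrogen. With compound 3 at a limit, the expected step that the limit leaves unreadable from compound 3 to compound 4 can only be stated as an estimate without a measured anchor. Compound 4 is expected to give about 12000 nM, in a range from 3000 nM to 40000 nM, with a fair chance that only a limit is reported.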

Compound 4, half-maximal effective concentration: > 10000 nM
Compound 4: a limit, no number; the forecaster's own chance of this, stated with the estimate: 60%; the middle value does not contradict the limit.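

Compound 3 and compound 4 are both recorded only as limits, so no step can be read between them: the limit of > 10000 nM in this assay, at which 2 of the 4 values shown sit.

The compounds shown leave open whether pyridin-2-yl or (dimethylamino)methyl at that place gives the lower number in this assay.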